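Working notes: compound 3 to compound 4 in the amide series

The source may hold more compounds than are shown below. What is called first, only, known or untested is meant among the compounds shown, and "the series" means these compounds.

Measured so far:
compound 1 `O=C(Nc1ccc(Cl)cc1)c1cc([N+](=O)[O-])ccc1Cl`: > 25000 nM
compound 2 `O=C(Nc1cccc(-c2nc3ccccc3s2)c1)c1ccc(Cl)nc1Cl`: > 25000 nM
compound 3 `Cc1ccc(-c2nc3ccccc3o2)cc1NC(=O)c1cnccc1Cl`: > 25000 nM

In an ADME assay on HEK293 cells (Homo sapiens) for inhibition, with a stated time of 72 h (on this read-out lower numbers stand for an effect already at smaller amounts and higher numbers for an effect only at larger amounts of compound), compound 1 gives > 25000 nM, which is a limit of the assay and not a number. Compound 2 gives > 25000 nM there, also a limit. Compound 3 gives > 25000 nM, again a limit. Compound 3 therefore stands at the limit of > 25000 nM in this assay, at which 3 of the 3 values shown sit, together with the other two. Compound 4 `O=C(Nc1cc(-c2nc3ccccc3o2)ccc1F)c1cnccc1Cl` is not yet measured. It differs from compound 3 by fluoro in place of methyl on an aromatic carbon. Within the data shown here, no step between measured compounds exists to draw on, and every value so far is a limit, so no shift beyond the scatter is expected in either direction. Compound 4 is expected to give 30000 nM, within 10000 nM to 100000 nM, most probably reported again as a limit. The expected step is a step that the limit leaves unreadable from compound 3 to compound 4.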

Compound 4, half-maximal effective concentration: > 25000 nM
Compound 4: no number, only a limit; the forecaster's own chance of this, stated with the estimate: 80%; the middle value lies beyond the limit too.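

Compound 3 and compound 4 both remain at a limit, so fluoro in place of methyl gives no readable step: the limit of > 25000 nM in this assay, at which 4 of the 4 values shown sit.

The compounds shown leave open whether any change to this amide series gives a measurable value in this assay.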